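A few compounds are considered here, and "the series" means these few. Any claim that something is new, unique, unknown or untested is made for them only; others in the source may bear on it.

In an ADME assay on HeLa cells (Homo sapiens) for cytotoxicity, read by XTT assay (on this read-out lower numbers stand for higher toxicity in this test and higher numbers for lower toxicity in this test), compound 1 `C1=C(CCCCCc2ccccc2)COc2ccccc21` gives 100000 nM, and compound 2 `c1ccc(CCCC2COc3ccccc3C2)cc1` gives 200000 nM. Compound 3 `Clc1ccc2c(c1)CC(CCCc1ccccc1)CO2` gives 200000 nM, level with compound 2 and within the scatter of compound 1. Compound 4 `Clc1cccc(CCCC2COc3ccc(Cl)cc3C2)c1` differs from compound 3 by one replacement, (chloro in place of hydrogen on an aromatic carbon), which turns phenyl to 3-chlorophenyl. Within the data shown here, one measured step bears on this: the same kind of replacement, chloro in place of hydrogen on an aromatic carbon, at a different place, gave no change at the digits printed from compound 2 to compound 3 (within the scatter). On that single step, no change beyond the scatter is expected in this assay, in either direction. The expected step is a 1.1-fold lower number from compound 3 to compound 4 (0.05 log units; within the scatter). Compound 4 is estimated at 180000 nM, with an expected range of 90000 nM to 350000 nM.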

Compound 4, half-maximal cytotoxic concentration: 200000 nM
Beside the measured number, compound 4's estimate is 1.1-fold (0.05 log units) below it; measured number inside the range.
By their numbers in this assay, from the lowest: compounds 1, 2, 3 and 4 (each within the scatter of the next).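

In this assay, phenyl to 3-chlorophenyl gives no change at the digits printed from compound 3 to compound 4 (within the scatter). Among these compounds, with the earlier replacement at a different place, no change at the digits printed from compound 2 to compound 3 (within the scatter), chloro in place of hydrogen on an aromatic carbon now reads flat at two places, and the second chloro adds nothing beyond the scatter to the one already in compound 3. Nothing on hand offers a reason for this flat reading. Still open, as far as these compounds go, is whether an amine or a carboxylic acid at this place would move the number beyond the scatter.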